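A few compounds are considered here, and "the series" means these few. Any claim that something is new, unique, unknown or untested is made for them only; others in the source may bear on it.

Working notes on the series, read in a functional assay on HCT-116 cells (Homo sapiens) for antiproliferative activity, with a stated time of 72 h; on this read-out higher numbers stand for weaker inhibition and lower numbers for stronger inhibition. Compound 1 (`CC(=O)Oc1ccccc1/C=C/c1nc2ccccc2c(=O)[nH]1`) reports only a limit, > 25000 nM. Going by the values given here, compound 2 (`COc1ccccc1/C=C/c1nc2ccccc2c(=O)[nH]1`) gives 2470 nM, the only exact number so far. Compound 3 (`CCOc1ccccc1/C=C/c1nc2ccccc2c(=O)[nH]1`) differs from compound 2 by methyl in place of hydrogen on a saturated chain carbon bound to an oxygen on an aromatic ring, so methoxy becomes ethoxy. Among the compounds with values here, one measured step bears on this oxygen, an at least 10-fold lower number from compound 1 to compound 2 (1.00 log units; beyond the scatter), with methyl in place of acetyl. That step lies beyond the scatter, but it exchanges a different group and sets no size for this smaller change. A small change is therefore expected, probably within the scatter and without a firm direction. The expected step is a 1.1-fold higher number from compound 2 to compound 3 (0.05 log units; within the scatter). For compound 3 the estimated value is 2800 nM, with an expected range from 1000 nM to 8000 nM.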

Compound 3, half-maximal inhibitory concentration: 23300 nM
The estimate for compound 3 lay 8.3-fold (0.92 log units) below the measured number, outside the stated range (above it).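

On this oxygen, methyl in place of hydrogen on a saturated chain carbon, which turns methoxy into ethoxy, gives a 9.4-fold higher number from compound 2 to compound 3 (0.97 log units; beyond the scatter), so the position responds to a change as small as one carbon, which the earlier exchange of methyl in place of acetyl could not show. In this assay, compound 2 has the lowest number of the three, and its steps to both other compounds lie beyond the scatter. Ethyl in place of acetyl on this oxygen gives an at least 1.0-fold lower number from compound 1 to compound 3 (0.03 log units; that floor lies within the scatter), and that floor sets no order between the two. Compound 1 carries only a limit: the limit of > 25000 nM in this assay, at which 1 of the 3 values shown sits.

On these data alone, whether a longer chain such as propyl on this oxygen would raise the number further, or a free hydroxyl would lower it, remains open. Also open, as far as these compounds go, is whether an amine in place of this oxygen would be tolerated as well as methoxy.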